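Fluoro to Trifluoromethyl on a Long-Lived Scaffold

The source may report more compounds than this note shows. Statements on the series, on what has been measured and on what is new or still open speak of the compounds shown alone.

For the measured compounds named here, compound 3 `CCC(/C=C1\OC(=O)NC1=O)(CC)c1ccc(-c2ccc3cccc(F)c3c2)[nH]c1=O` is one of three compounds measured in an ADME assay on microsomes from liver (Rattus norvegicus) for metabolic stability; a lower number here means that the compound disappears faster, a higher number that the compound lasts longer. In this assay compound 3 gives > 3 h, which is a limit of the assay and not a number. Compound 1 `CCC(/C=C1\OC(=O)NC1=O)(CC)c1ccc(-c2ccc3cc(F)cc(F)c3c2)[nH]c1=O` differs from it by hydrogen in place of fluoro on an aromatic carbon. In this assay compound 1 gives > 3 h, again a limit. The step that the two limits leave unreadable from compound 1 to compound 3 therefore cannot be read, since both values sit at the limit of > 3 h in this assay, at which 2 of the 3 values shown sit. Compound 2 `CC(C)C(c1ccc(-c2ccc3cccc(F)c3c2)[nH]c1=O)C1C(=O)NC(=O)N1C` has a different core and side arm, and in this assay compound 2 gives 0.263 h.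

Compound 4 `CCC(/C=C1\OC(=O)NC1=O)(CC)c1ccc(-c2ccc3cccc(C(F)(F)F)c3c2)[nH]c1=O` differs from compound 3 in one place: trifluoromethyl in place of fluoro on an aromatic carbon. Going by the values given here, the only measured step that bears on this region is the unreadable one from compound 1 to compound 3, so nothing quantitative is known about swapping groups on this ring. Compound 3 already stands at the limit, and only a drop beyond the scatter would bring compound 4 into the readable range. Compound 4 is expected to give about 3.5 h, within 1.5 h to 8 h. The expected step that the limit leaves unreadable from compound 3 to compound 4 is estimated to stay within the scatter.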

Compound 4, half-life: 1.09 h
Compound 4: middle estimate off by 3.2-fold (0.51 log units), on the high side; measured number outside the range, below it.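

Swapping fluoro for trifluoromethyl on this ring gives an at least 2.7-fold lower number from compound 3 to compound 4 (0.43 log units; beyond the scatter) in this assay, so this carbon does not tolerate every group, and the long-lived scaffold can lose stability through a change at this one place. For the compounds shown here, this is the first step on this ring that can be read, since the earlier pair, compound 1 and compound 3, gave only limits. The size of the step is only a minimum because the value of compound 3 is a limit: the limit of > 3 h in this assay, at which 2 of the 4 values shown sit.

The compounds shown leave open whether a methyl group, a chlorine atom or a methoxy group on this same carbon would keep the half-life of compound 3 or lower it as trifluoromethyl does. They also do not show which part of compound 4 is broken down in the microsomes.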